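Lengthening a thiourea chain on a sugar-like pyrrolidine core

A few compounds are considered here, and "the series" means these few. Any claim that something is new, unique, unknown or untested is made for them only; others in the source may bear on it.

Compound 1 `CCCCCCCCNC(=S)N1[C@H](CO)[C@@H](O)[C@H](O)[C@H]1CO` and compound 2 `CCCCNC(=S)N1[C@@H](CO)[C@H](O)[C@@H](O)[C@@H]1CO` were tested in an assay for inhibition of beta-galactosidase (Bos taurus), read by spectrophotometry; on this read-out lower numbers stand for stronger inhibition and higher numbers for weaker inhibition. Compound 1 gives 414000 nM, and compound 2 gives 473000 nM; compound 2 holds the highest of the two numbers, yet its gap to compound 1 lies within the scatter. Compound 3 `CCCCCCCCNC(=S)N1[C@@H](CO)[C@H](O)[C@@H](O)[C@@H]1CO` shares the core of compound 2 and differs by butyl in place of hydrogen on a saturated chain carbon, four bonds along the chain from an amide-type nitrogen. Since compound 1 already shows an octyl chain at 414000 nM, no step beyond the scatter is expected from compound 2 to compound 3, estimated as a 1.2-fold lower number from compound 2 to compound 3 (0.07 log units; within the scatter). Compound 3 is therefore expected near 400000 nM, within 150000 nM to 1000000 nM.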

Compound 3, half-maximal inhibitory concentration: 266000 nM
Beside the measured number, compound 3's estimate is 1.5-fold (0.18 log units) above it; the range from low to high includes it.
By their numbers in this assay, from the lowest: compounds 3, 1 and 2 (each within the scatter of the next).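

In this assay, butyl in place of hydrogen at this chain position gives a 1.8-fold lower number from compound 2 to compound 3 (0.25 log units; within the scatter), so the longer chain brings no change that can be told from repeat measurement. Inverting every stereocentre gives a 1.6-fold lower number from compound 1 to compound 3 (0.19 log units; within the scatter), so the mirror-image pair cannot be told apart on this read-out either. This second comparison concerns configuration alone: the fact that compounds 1 and 3 differ only in the configuration as drawn

On these data alone, it remains open whether a longer chain such as dodecyl, or a carboxylic acid in place of the butyl, would move the number beyond the scatter.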